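Thiophene variation on the pyrazoline core: cytotoxicity notes

This account rests on a few compounds, and the source may have more. Where it says the series, first, only, none or still open, it means among the compounds named here.

Measured so far:
compound 1 `Cc1ccsc1C1=NNC(c2ccc(N3CCCCC3)cc2)C1` 11000 nM
compound 2 `Cc1cc(C2=NNC(c3ccc(N4CCCCC4)cc3)C2)c(C)s1` 77500 nM
compound 3 `Clc1ccc(C2=NNC(c3ccc(N4CCCCC4)cc3)C2)s1` > 100000 nM

All three share a core and differ only in the thiophene attached on a carbon with a double bond to nitrogen. In an ADME assay on PBMC cells (Homo sapiens) for cytotoxicity, with a stated time of 5 days (on this read-out higher numbers stand for weaker inhibition and lower numbers for stronger inhibition), compound 1 gives 11000 nM. Compound 2, with 2,5-dimethylthiophen-3-yl, gives 77500 nM, a step of a 7.0-fold higher number from compound 1 to compound 2 (0.85 log units; beyond the scatter). Compound 3 reaches only a limit of this assay, > 100000 nM, so its true number is not known; it sits at the limit of > 100000 nM in this assay, at which 1 of the 3 values shown sits. The step of an at least 9.0-fold higher number from compound 1 to compound 3 (0.95 log units; beyond the scatter) is therefore a floor, and an at least 1.2-fold higher number from compound 2 to compound 3 (0.11 log units; that floor lies within the scatter) is likewise only a floor.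

The next compound, compound 4 `Brc1ccsc1C1=NNC(c2ccc(N3CCCCC3)cc2)C1`, is reached by the change (3-bromothiophen-2-yl in place of 5-chlorothiophen-2-yl on a carbon with a double bond to nitrogen). Among the measured compounds, compound 1 also carries a thiophen-2-yl bearing a group at the 3-position, and compound 1 gives 11000 nM. Compound 3, by contrast, stands only at a limit of this assay. For the measured compounds named here, the steps that bear on the change are those into compound 3, both open-ended. A number below the limit is expected for compound 4, a step of an at least 3.3-fold lower number from compound 3 to compound 4 (0.52 log units; beyond the scatter), though with wide uncertainty since compound 3 is only a limit. The estimate for compound 4 is 30000 nM, between 8000 nM and 100000 nM.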

Compound 4, half-maximal inhibitory concentration: 57000 nM
Estimate against measurement, compound 4: 1.9-fold (0.28 log units) below; the measured number falls inside the stated range.
By their numbers in this assay, from the lowest: compound 1; then compounds 4 and 2 (each within the scatter of the next). At a limit, above all of these: compound 3.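

In this assay, for the compounds shown here, the step of a 5.2-fold higher number from compound 1 to compound 4 (0.71 log units; beyond the scatter) is beyond the scatter, and it is the first comparison in which the thiophen-2-yl attachment stays fixed and a single substituent, bromo in place of methyl, changes. The number at this position therefore responds to that one swap, although the data give no reason for it. The step of a 1.4-fold lower number from compound 2 to compound 4 (0.13 log units; within the scatter) lies within the scatter, so 3-bromothiophen-2-yl and 2,5-dimethylthiophen-3-yl cannot be ordered here, and the step of an at least 1.7-fold lower number from compound 3 to compound 4 (0.24 log units; that floor lies within the scatter) rests on a limit of the assay and cannot be read as a difference: the limit of > 100000 nM in this assay, at which 1 of the 4 values shown sits.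

The change from 5-chlorothiophen-2-yl to 3-bromothiophen-2-yl alters both the halogen and its place on the thiophene, so the contribution of each remains unresolved. Also open, as far as these compounds go, is how the same thiophen-2-yl would read in this assay with a chloro, a methoxy, an amine or a carboxylic acid in the place held by the methyl of compound 1 and the bromo of compound 4.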